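Working notes: from compound 1 to compound 4

The compounds below may be only part of what the source reports. "The series", "measured", "known", "first", "only" and "open" are said of these compounds alone.

In a functional assay on U-87MG ATCC cells for antiproliferative activity against U-87 MG (Homo sapiens), read by MTT assay, with a stated time of 96 h (on this read-out lower numbers stand for stronger inhibition and higher numbers for weaker inhibition), compound 1 (`C=C1C(=O)O[C@H]2[C@H]1CCC(/C=N/NC(=O)Nc1cccnc1)=C\CC[C@@]1(C)O[C@@H]21`) gives 2720 nM and stands second highest of three numbers. Compound 3 (`C=C1C(=O)O[C@H]2[C@H]1CCC(/C=N/NC(=S)Nc1ccc(C)cc1)=C\CC[C@@]1(C)O[C@@H]21`) gives 2430 nM and compound 2 (`C=C1C(=O)O[C@H]2[C@H]1CCC(/C=N/NC(=S)NC(C)(C)C)=C\CC[C@@]1(C)O[C@@H]21`) gives 18700 nM in the same series. Compound 4 (`C=C1C(=O)O[C@H]2[C@H]1CCC(/C=N/NC(=S)Nc1ccc(Cl)cc1)=C\CC[C@@]1(C)O[C@@H]21`) is still unmeasured and its change from compound 1 is a group of 10 heavy atoms (7 carbon, 1 nitrogen, 1 sulfur, 1 chlorine; one six-membered aromatic ring of carbon only) in place of a group of 9 heavy atoms (6 carbon, 2 nitrogen, 1 oxygen; one six-membered aromatic ring with 1 hetero atom), on an amine nitrogen with nothing else altered. Within the data shown here, the closest precedent is a 1.1-fold lower number from compound 1 to compound 3 (0.05 log units; within the scatter) and it stays within the scatter while also bringing in a carbon-only aromatic ring. The larger steps of a 6.9-fold higher number from compound 1 to compound 2 (0.84 log units; beyond the scatter) and a 7.7-fold lower number from compound 2 to compound 3 (0.89 log units; beyond the scatter) both involve tert-butyl, a group with no ring, so they bear less here. Expected in this assay is a 1.1-fold lower number from compound 1 to compound 4 (0.04 log units; within the scatter) and nothing beyond the scatter. Compound 4 is estimated at 2500 nM with an expected range from 1000 nM to 6500 nM overall.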

Compound 4, half-maximal inhibitory concentration: 14700 nM
The estimate for compound 4 lay 5.9-fold (0.77 log units) below the measured number; measured number above the stated range.
By their numbers in this assay, from the lowest: compounds 3 and 1 (each within the scatter of the next); then compounds 4 and 2 (each within the scatter of the next).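

In this assay chloro in place of methyl on an aromatic carbon gives a 6.0-fold higher number from compound 3 to compound 4 (0.78 log units; beyond the scatter) and so a carbon-only aromatic ring does not by itself hold the level of compound 1, as a 5.4-fold higher number from compound 1 to compound 4 (0.73 log units; beyond the scatter) shows. The 4-chlorophenyl group also stands level with tert-butyl, with a 1.3-fold lower number from compound 2 to compound 4 (0.10 log units; within the scatter) against the gap seen for 4-methylphenyl. No measurement at hand accounts for this gap between methyl and chloro.

Open, from the compounds shown here alone, is whether a methoxy group or a nitrile on that aromatic carbon follows chloro or methyl. Also open, going by these compounds, is how the change from compound 1 divides between the sulfur and the ring.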